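Compound 1 and a sulfur-bearing replacement group

This account rests on a few compounds, and the source may have more. Where it says the series, first, only, none or still open, it means among the compounds named here.

Values in an ADME assay on the whole organism (Mus musculus, strain CD-1) for pharmacokinetics, at a dose of 10 mg/kg by the oral route (a lower number here means that a smaller share of the oral dose reaches the circulation, a higher number that a larger share of the oral dose reaches the circulation), for three compounds:
- compound 1 `COc1cc([C@](O)(CCN(C)C)[C@@H](c2cc3cc(Br)ccc3nc2OC)c2cccc(OC)c2F)cc(OC(C)C)n1` gives 43%
- compound 2 `COc1cc([C@](O)(CCN(C)C)[C@@H](c2cc3cc(Br)ccc3nc2OC)c2ccnc(OC)c2OC)cc(OC(C)C)n1` gives 22%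
- compound 3 `COc1cccc([C@H](c2cc3cc(C#N)ccc3nc2OC)[C@@](O)(CCN(C)C)c2cc(SC)nc(SC)c2)c1F` gives 28%

Compound 1 stands highest of the three, with compound 3 and compound 2 both lower beyond the usual scatter. Compound 4 `CCSc1cc([C@](O)(CCN(C)C)[C@@H](c2cc3cc(Br)ccc3nc2OC)c2cccc(OC)c2F)cc(SCC)n1` is still unmeasured. Its structural change is a group of 12 heavy atoms (9 carbon, 1 nitrogen, 2 sulfur; one six-membered aromatic ring with 1 hetero atom) in place of a group of 12 heavy atoms (9 carbon, 1 nitrogen, 2 oxygen; one six-membered aromatic ring with 1 hetero atom), on a saturated chain carbon bound to an oxygen on a saturated carbon and two saturated chain carbons. Among the measured compounds shown here, the only measured single-place step, a number 21 percentage points lower from compound 1 to compound 2 (beyond the scatter), lies at another place and bears on this change only indirectly. Closer in kind is compound 3, also sulfur-bearing, at 28%, although it differs from compound 1 elsewhere too. A modest fall is therefore expected, with the estimated change being a number 13 percentage points lower from compound 1 to compound 4 (beyond the scatter). Compound 4 is expected to give 30%, within an estimated range of 15% to 45%.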

Compound 4, oral bioavailability: 25%
Estimate against measurement, compound 4: 5 percentage points above; measured number inside the range.
By their numbers in this assay, from the lowest: compounds 2, 4 and 3 (each within the scatter of the next); then compound 1.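

At this position, on a saturated chain carbon bound to an oxygen on a saturated carbon and two saturated chain carbons, this assay now has its first single-place reading: the group with 2 sulfur in place of the group with 2 oxygen gives a number 18 percentage points lower from compound 1 to compound 4 (beyond the scatter) on the core of compound 1. The number falls although the heavy-atom count, hydrogen-bond acceptors and donors, and net charge of the group are unchanged. No available evidence explains this fall. The compounds shown leave open whether replacing one oxygen alone would give a similar step. They also leave open how an amine or a longer chain on this ring would read.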